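Trimming the Ethoxy Chain on a Shared Core

The source may report more compounds than this note shows. Statements on the series, on what has been measured and on what is new or still open speak of the compounds shown alone.

Measured compounds:
- Compound 1 `CCCNc1nc(N)c2nc(O)n(Cc3ccccc3)c2n1`: 0.1 uM
- Compound 2 `CCCC[S+]([O-])c1nc(N)c2nc(O)n(Cc3ccccc3)c2n1`: 0.01 uM
- Compound 3 `CCOc1nc(N)c2nc(O)n(Cc3ccccc3)c2n1`: 0.1 uM

All three compounds were tested in a functional assay (spleen, spleen) for activation, with Mus musculus as the target; on this read-out higher numbers stand for an effect only at larger amounts of compound and lower numbers for an effect already at smaller amounts. Compound 3 stands level with compound 1, since no change at the digits printed from compound 1 to compound 3 (within the scatter); together these two give the highest numbers of the three. Compound 2 is the one that acts at smaller amounts: a 10-fold higher number from compound 2 to compound 3 (1.00 log units; beyond the scatter), and likewise a 10-fold lower number from compound 1 to compound 2 (1.00 log units; beyond the scatter).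

Compound 4 `COc1nc(N)c2nc(O)n(Cc3ccccc3)c2n1` has not yet been measured. It differs from compound 3 in one place: hydrogen in place of methyl on a saturated chain carbon bound to an oxygen on an aromatic ring. Read one bond further out, this is ethoxy to methoxy, a small shortening of the side chain.

Among the compounds with values here, only one measured step resembles this change. Going from compound 1 to compound 3 replaced propylamino with ethoxy, a change in the same part of the molecule that also removed a heavy atom from the chain, and the number in this assay did not move beyond the scatter. The steps involving compound 2 concern a much larger group and say little about a single carbon. On that basis, the step from compound 3 to compound 4 is expected to stay within the scatter, perhaps tilting toward a slightly higher number: a 1.5-fold higher number from compound 3 to compound 4 (0.18 log units; within the scatter). Compound 4 is therefore estimated at 0.15 uM, with a range from 0.05 uM to 0.5 uM.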

Compound 4, minimum effective concentration: 0.1 uM
The estimate for compound 4 lay 1.5-fold (0.18 log units) above the measured number, and the stated range covers the measured number.
By their numbers in this assay, from the lowest: compound 2; then compounds 1, 3 and 4 (each within the scatter of the next).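

Shortening the chain from ethoxy to methoxy in this assay gives no change at the digits printed from compound 3 to compound 4 (within the scatter) and so adds the first direct read on this single carbon: on a saturated chain carbon bound to an oxygen on an aromatic ring, the methyl can give way to hydrogen without a change that stands out from the scatter. Methoxy also matches the propylamino group, with no change at the digits printed from compound 1 to compound 4 (within the scatter) as the printed step, which places three different groups on the same aromatic carbon at one level in this read-out and shows that this level does not depend on the single carbon just removed. Within the data shown here, the group of compound 2 still stands apart, as a 10-fold higher number from compound 2 to compound 4 (1.00 log units; beyond the scatter) shows, so the shortest chain here does not close that gap and compound 2 remains the only compound separated from the others.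

On these data alone, whether a longer chain on the oxygen, such as butoxy, or a hydroxyl or primary amine on the aromatic carbon would stay at this level or reach the number of compound 2 remains open. Nothing available here explains why these numbers fall as they do.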